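Removing a Chloro Group from an Inactive Hydrazone

A few compounds are considered here, and "the series" means these few. Any claim that something is new, unique, unknown or untested is made for them only; others in the source may bear on it.

Compound 2 `COc1ccc(OC)c(/C=C/C(=O)N/N=C/c2ccc(Cl)cc2)c1`: > 100000 nM
Compound 1 `COc1ccc(OC)c(/C=C/c2nnc(Nc3ccc(Cl)cc3)o2)c1`: > 100000 nM

In a functional assay on SNB-75 cells (Homo sapiens) for antiproliferative activity, read by sulforhodamine B assay, with a stated time of 48 h (a lower number here means that less compound is tolerated, a higher number that more compound is tolerated), compound 2 reaches only a limit, > 100000 nM, not a measured number. Compound 1 also stops at a limit, > 100000 nM. Both sit at the limit of > 100000 nM in this assay, at which 2 of the 2 values shown sit. Going by the values given here, compound 3 `COc1ccc(OC)c(/C=C/C(=O)N/N=C/c2ccccc2)c1` differs from compound 2 by hydrogen in place of chloro on an aromatic carbon, with no measured step of this kind to lean on. The expected step that the limit leaves unreadable from compound 2 to compound 3 is none beyond the usual scatter, since compound 2 shows only > 100000 nM. Compound 3 is estimated at 200000 nM, within 50000 nM to 1000000 nM, most likely again reported only as a limit.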

Compound 3, concentration lethal to 50% of the cells: > 100000 nM
Compound 3: a limit, no number (the forecaster's own chance of this, stated with the estimate: 85%); the middle value is on the limit's open side.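

Going by these compounds alone, compound 2 and compound 3 both stop at a limit, so no step between them can be read: the limit of > 100000 nM in this assay, at which 3 of the 3 values shown sit. The compounds shown leave open what hydrogen in place of chloro does in this assay: none of them gives a measured number.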